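The compounds below may be only part of what the source reports. "The series", "measured", "known", "first", "only" and "open" are said of these compounds alone.

Compound 2 `CCSc1nn2cc(-c3cc4ccccc4o3)nc2s1` has no number in an assay for antagonist activity at proteinase-activated receptor 4 (Homo sapiens), with stated times of 5 min, 50 s and 15 min, in the presence of a further agent that is not named here; a higher number here means a weaker inhibitor, a lower number a stronger inhibitor; its entry reads "not determined" (no result reported). Two other compounds share its core. Compound 1 `COc1ccc2oc(-c3cn4nc(OC)sc4n3)cc2c1` reaches only the limit of the assay, > 30000 nM, which is not a number. Compound 3 `COc1nn2cc(-c3cc4ccc(OCc5ccccc5)cc4o3)nc2s1` gives 1800 nM in this assay. Compound 4 `CCOc1nn2cc(-c3cc4ccccc4o3)nc2s1` is compound 2 with ethoxy in place of ethylsulfanyl on an aromatic carbon, next to the ring nitrogen and next to the ring sulfur of the five-membered ring. Among the compounds with values here, no measured pair shows this change, so no direction can be read from the data; in this assay a step no larger than the usual scatter is expected, in no set direction. Compound 4 is expected to be a weak inhibitor at about 15000 nM, between 3000 nM and 60000 nM.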

Compound 4, half-maximal inhibitory concentration: 2100 nM
Compound 4: middle estimate off by 7.1-fold (0.85 log units), on the high side, outside the stated range (below it).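

Compound 2 has no number to set against compound 4, so no step can be read between them. Nothing shown bears on the value of compound 4. From the compounds shown here alone, whether exchanging ethylsulfanyl for ethoxy changes inhibition stays open.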